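Methyl Addition to Two Related Cores and Cytotoxicity

The compounds below may be only part of what the source reports. "The series", "measured", "known", "first", "only" and "open" are said of these compounds alone.

The measured compounds in a functional assay on CCRF-CEM cells (Homo sapiens) for cytotoxicity; a higher number here means that more compound is tolerated, a lower number that less compound is tolerated:
compound 1, `Cc1ncn2c(S)ncnc12`, 789000 nM
compound 2, `Cc1nc(C)n2c(S)ncnc12`, > 694000 nM, a limit of the assay
compound 3, `CSC1N=CNc2c(C)ncn21`, 176000 nM

Compound 1 and compound 2 share a core and differ by methyl in place of hydrogen on an aromatic carbon. In this assay compound 2 gives only a limit, > 694000 nM. The step that the limit leaves unreadable from compound 1 to compound 2 therefore cannot be read, because of the limit of > 694000 nM in this assay, at which 1 of the 3 values shown sits. Compound 3 carries a different core; how the core of compound 3 differs from the core of compound 1 is not broken down here. In this assay compound 3 gives the lowest number, and its nearest neighbour is compound 1, whose number lies higher by more than the usual scatter.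

Compound 4, `CSC1N=CNc2c(C)nc(C)n21`, has not yet been measured. It differs from compound 3 by methyl in place of hydrogen on an aromatic carbon. This is the same kind of change as that from compound 1 to compound 2, though here the methyl enters next to the ring atom that bears a fused ring, two ring bonds from the ring atom that bears a fused ring.

Within the data shown here, for compound 4 in this assay the step of a 1.4-fold higher number from compound 3 to compound 4 (0.15 log units; within the scatter) is expected, a small one, since the only comparable step is unreadable and the limit of compound 2 gives no sign of a large drop. Compound 4 is estimated at 250000 nM, with a range from 100000 nM to 700000 nM.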

Compound 4, half-maximal cytotoxic concentration: 440000 nM
Compound 4: the middle estimate sits 1.8-fold (0.25 log units) below what was measured; the range from low to high includes it.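

In this assay, methyl in place of hydrogen on an aromatic carbon gives a 2.5-fold higher number from compound 3 to compound 4 (0.40 log units; beyond the scatter), so on the core of compound 3 the change moves the number up, a modest but readable step towards more compound tolerated. The same change on the core of compound 1 cannot be read, because compound 2 gives only a limit: the limit of > 694000 nM in this assay, at which 1 of the 4 values shown sits. The change can therefore be sized on one core only, and the data do not show whether the step carries over from one core to the other with the same size or even the same direction, nor do they offer any reason why the number moves on the core of compound 3.

The compounds shown leave open whether a group other than methyl on that aromatic carbon, such as an ethyl group, an amine or a carboxylic acid, would move the number in this assay on either core, and if so how far. They also leave open whether a longer chain there would extend the step seen with compound 4 or reverse it, since a single readable step gives no trend to follow.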